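Shift from 3-bromophenyl to thiophen-2-yl on the core

This account rests on a few compounds, and the source may have more. Where it says the series, first, only, none or still open, it means among the compounds named here.

Compound 1 `O=C(O)CCc1ccc(OCc2coc(-c3cccc(Cl)c3)n2)cc1` gives 160 nM in a functional assay on CHO cells for agonist activity at Free fatty acid receptor 1 (Homo sapiens), read by FLIPR and calcium flux, in the presence of a further agent that is not named here; on this read-out lower numbers stand for an effect already at smaller amounts and higher numbers for an effect only at larger amounts of compound. Compound 2 `O=C(O)CCc1ccc(OCc2nc(-c3cccc(Br)c3)no2)cc1` gives 1260 nM in this assay, the second highest of the three numbers shown; the nearest is compound 1, whose value is lower by a gap beyond the scatter, and the furthest is compound 3 `O=C(O)CCc1ccc(OCc2nc(-c3cccc(C(F)(F)F)c3)no2)c(Cl)c1`, which in this assay gives 30100 nM, a gap beyond the scatter as well. For the measured compounds named here, no step between two compounds that differ in one place is available, so no measured step informs the change to compound 4 `O=C(O)CCc1ccc(OCc2nc(-c3cccs3)no2)cc1`. That change, (thiophen-2-yl in place of 3-bromophenyl on an aromatic carbon), replaces a six-membered ring by a smaller five-membered one. A weakening beyond the scatter is expected, a 2.8-fold higher number from compound 2 to compound 4 (0.44 log units; beyond the scatter). Compound 4 is estimated at 3500 nM, within 1000 nM to 12000 nM.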

Compound 4, half-maximal effective concentration: 2570 nM
For compound 4 the middle estimate is 1.4-fold (0.13 log units) above the measured one, within the range that was stated.
By their numbers in this assay, from the lowest: compound 1; then compound 2; then compound 4; then compound 3.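

At the aromatic carbon between two ring nitrogen atoms, thiophen-2-yl in place of 3-bromophenyl gives a 2.0-fold higher number from compound 2 to compound 4 (0.31 log units; beyond the scatter) in this assay. For the compounds shown here, this is the first one-place step, and it shows that replacing the six-membered ring with a five-membered aromatic ring carrying sulfur changes the number only modestly. Nothing available explains the direction or size of this step.

The compounds shown do not separate the loss of the bromine atom from the change of ring. Going by these compounds, it remains open where an unsubstituted phenyl or a thiophen-3-yl group would fall at this position.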